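The source may report more compounds than this note shows. Statements on the series, on what has been measured and on what is new or still open speak of the compounds shown alone.

Of the compounds shown here, three sharing a core have been tested in an ADME assay on L6 cells (Rattus norvegicus) for cytotoxicity, read by resazurin assay, with a stated time of 72 h; on this read-out higher numbers stand for weaker inhibition and lower numbers for stronger inhibition. Compound 1 `OC(c1ccc(Cl)cc1)(c1ccc(Br)cc1)c1cccnc1` gives 57000 nM, and compound 2 `OC(c1ccc(Cl)cc1)(c1cccnc1)c1cccs1` gives 67700 nM. Compound 3 `OC(c1ccc(Cl)cc1)(c1cccnc1)c1ccsc1` returns no number, only a limit, > 100000 nM.

Compound 4 `OC(c1ccc(Cl)cc1)(c1cccnc1)c1cncs1` departs from compound 3 in one place: 1,3-thiazol-5-yl in place of thiophen-3-yl on a saturated chain carbon bound to two aromatic carbons and an oxygen on a saturated carbon. The measured steps at this same place are the nearest guide. They are a 1.2-fold higher number from compound 1 to compound 2 (0.07 log units; within the scatter), an at least 1.7-fold higher number from compound 1 to compound 3 (0.24 log units; that floor lies within the scatter) and an at least 1.4-fold higher number from compound 2 to compound 3 (0.16 log units; that floor lies within the scatter). As far as these compounds go, all three lie within the scatter, and the last two are floors only, so their true sizes remain open. Exchanging one five-membered aromatic ring for another has so far produced no step beyond the scatter, although only compound 2 and compound 3 show that exchange. No step beyond the scatter is therefore expected in this assay, in either direction. The expected change is an at least 1.1-fold lower number from compound 3 to compound 4 (0.07 log units; that floor lies within the scatter). For compound 4 the estimated value is 85000 nM, with an expected range from 40000 nM to 160000 nM.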

Compound 4, half-maximal inhibitory concentration: > 100000 nM
Compound 4: only a limit was reported (the forecaster's own chance of this, stated with the estimate: 45%); at least 1.1-fold (0.07 log units) between middle value and limit.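

In this assay, compound 4 returns only a limit, > 100000 nM, so 1,3-thiazol-5-yl at this place gives a second compound without a number. Its readable steps are floors, an at least 1.4-fold higher number from compound 2 to compound 4 (0.16 log units; that floor lies within the scatter) and an at least 1.7-fold higher number from compound 1 to compound 4 (0.24 log units; that floor lies within the scatter), and they match those of compound 3, while the step between compound 3 and compound 4 cannot be read, as both ends are limits. A second hetero atom in the five-membered aromatic ring therefore did not bring a number back into range, and the limit now recurs in the series: the limit of > 100000 nM in this assay, at which 2 of the 4 values shown sit.

As far as these compounds go, the true values of compound 3 and compound 4 stay open, and with them any difference between thiophen-3-yl and 1,3-thiazol-5-yl. Also open, from the compounds shown here alone, is whether an amine or a carboxylic acid at this place would give a number in this assay.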